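This account rests on a few compounds, and the source may have more. Where it says the series, first, only, none or still open, it means among the compounds named here.

Measured so far:
- compound 1, `CCCCCCCCCCCCCCCCCCNC(=O)[C@H]1CSC(c2c[nH]c3ccccc23)N1`, gives 1300 nM in a functional assay on PPC-1 cells (Homo sapiens) for antiproliferative activity, read by sulforhodamine B assay; a higher number here means a weaker inhibitor, a lower number a stronger inhibitor
- compound 2, `CCCCCCCCCCCCCCCCCCNC(=O)[C@H]1CSC(c2ccc(C#N)cc2)N1`, gives 5000 nM in this assay

Compound 2 stands highest of the two numbers; its nearest neighbour is compound 1, and the step of a 3.8-fold higher number from compound 1 to compound 2 (0.59 log units; beyond the scatter) lies beyond the scatter. Compound 3, `CCCCCCCCCCCCCCCCCCNC(=O)[C@H]1CSC(c2ccc(C)cc2)N1`, differs from compound 2 by methyl in place of cyano on an aromatic carbon. No measured step involves this exchange, since the only step shown swaps the whole aryl group rather than a single substituent on it. Compound 3 is therefore expected to give a number close to compound 2, with the step of a 1.3-fold lower number from compound 2 to compound 3 (0.10 log units; within the scatter) not expected to exceed the scatter. Compound 3 is estimated at 4000 nM, within 1500 nM to 12000 nM.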

Compound 3, half-maximal inhibitory concentration: 1900 nM
The estimate for compound 3 lay 2.1-fold (0.32 log units) above the measured number; measured number inside the range.
By their numbers in this assay, from the lowest: compounds 1 and 3 (each within the scatter of the next); then compound 2.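

In this assay the exchange of cyano for methyl gives a 2.6-fold lower number from compound 2 to compound 3 (0.42 log units; beyond the scatter) and so shows that a single substituent on this aromatic ring, para to a large group, can move the number on its own. With 4-methylphenyl in place of 1H-indol-3-yl the result is a 1.5-fold higher number from compound 1 to compound 3 (0.16 log units; within the scatter) and so, unlike 4-cyanophenyl, this aryl group stays within the scatter of the indole-bearing compound 1. Nothing available explains these differences. Going by these compounds, how an amine or a methoxy group at this place would compare remains open. So does the effect of a shorter chain on the amide.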